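This account rests on a few compounds, and the source may have more. Where it says the series, first, only, none or still open, it means among the compounds named here.

Three compounds share one core and differ only in the aryl group attached to an amine nitrogen. Compound 1 `CC1CC/C(=N\Nc2ccccc2Cl)c2ncc(C(=O)O)c(=O)n21` was tested in a functional assay on the whole organism for inhibition, with Rattus norvegicus as the target; on this read-out lower numbers stand for an effect already at smaller amounts and higher numbers for an effect only at larger amounts of compound. For compound 1 the result is a limit, > 1000 umol/kg, and not a number. Compound 2 `CC1CC/C(=N\Nc2cccc(Br)c2)c2ncc(C(=O)O)c(=O)n21` likewise reaches only a limit in this assay, > 320 umol/kg. Compound 3 `COc1ccccc1N/N=C1\CCC(C)n2c1ncc(C(=O)O)c2=O` again gives a limit in this assay, > 1000 umol/kg. Compound 3 thus stands at the limit of > 1000 umol/kg in this assay, at which 2 of the 3 values shown sit, whereas compound 2 sits at the limit of > 320 umol/kg in this assay, at which 1 of the 3 values shown sits. The steps a step that the two limits leave unreadable from compound 1 to compound 2, a step that the two limits leave unreadable from compound 1 to compound 3 and a step that the two limits leave unreadable from compound 2 to compound 3 have no readable size; each of the three values is a limit. Compound 4 `COc1ccc(N/N=C2\CCC(C)n3c2ncc(C(=O)O)c3=O)cc1` is not yet measured and differs from compound 3 by 4-methoxyphenyl in place of 2-methoxyphenyl on an amine nitrogen. Among the measured compounds shown here, no measured step offers a readable size, so nothing points to a change beyond the scatter in either direction. Compound 4 is therefore expected to remain near the same limit in this assay, with an estimated step of a number no higher from compound 3 to compound 4 (the limit leaves the size open). The estimate for compound 4 is 1000 umol/kg, within 300 umol/kg to 3000 umol/kg, and the assay is expected most likely to report only a limit again.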

Compound 4, dose for 50% inhibition: 7.6 umol/kg
Compound 4: middle estimate off by 130-fold (2.12 log units), on the high side, and the stated range ends above it.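

In this assay, the position of the methoxy group on the aryl ring matters greatly: 4-methoxyphenyl in place of 2-methoxyphenyl on the amine nitrogen gives an at least 130-fold lower number from compound 3 to compound 4 (2.11 log units; beyond the scatter) even though the two compounds hold the same atoms, joined differently. Compounds 1, 2 and 3 gave only limits, so the steps among them cannot be read, but the new value yields an at least 42-fold lower number from compound 2 to compound 4 (1.62 log units; beyond the scatter) and an at least 130-fold lower number from compound 1 to compound 4 (2.11 log units; beyond the scatter) as well. Among these four compounds, then, the aryl group on this nitrogen, and where its substituent sits, can make a large difference on the shared core.

Nothing measured here explains why the 4-methoxyphenyl group stands apart. On these data alone, whether an ethoxy or a hydroxyl group in place of the methoxy group of compound 4 would keep this effect remains open.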